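A few compounds are considered here, and "the series" means these few. Any claim that something is new, unique, unknown or untested is made for them only; others in the source may bear on it.

Compound 1, `C=CC(=C)CC[C@@H]1[C@@]2(C)CCC[C@](C)(COC(=O)/C=C/c3ccc(O)cc3)[C@@H]2CC[C@@]1(C)O`, gives 16600 nM in a functional assay on MCF7 cells (Homo sapiens) for cytotoxicity, read by MTT assay, with a stated time of 48 h; a lower number here means a stronger inhibitor, a higher number a weaker inhibitor.
Compound 2, `C=CC(=C)[C@@H](O)C[C@H]1C(=C)CC[C@@H]2[C@]1(C)CCC[C@]2(C)C(=O)O`, gives > 40000 nM in this assay; this is a limit of the assay, not a number.
Compound 3, `C=C1CC[C@@H]2[C@](C)(CCC[C@@]2(C)C(=O)O)[C@H]1CC/C(C)=C/COC(C)=O`, gives > 40000 nM in this assay; this too is a limit of the assay and not a number.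

Compound 2 therefore stands at the edge of what this assay can report: only a limit is known for it, and it shares that position with one other compound, as the limit of > 40000 nM in this assay, at which 2 of the 3 values shown sit, shows. Compound 1 is the only one of the three with an actual number, and that number sits well toward the weak end.

Compound 4, `C=CC(=C)[C@H](O)C[C@H]1C(=C)CC[C@@H]2[C@]1(C)CCC[C@]2(C)C(=O)O`, has not yet been measured in this assay. It differs from compound 2 as follows: the two compounds have the same atoms and bonds and differ only in configuration as drawn: 1 of 5 stereo elements differ; a stereocentre at a saturated chain carbon is drawn S in compound 2 and R in compound 4. Among the compounds with values here, no pair of measured compounds differing in a single place is available, so no measured step can be called on for guidance.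

Given that compound 2 sits at the limit, the change of configuration at one stereocentre is expected to shift the result by no more than the usual scatter, so the step that the limit leaves unreadable from compound 2 to compound 4 is estimated to be essentially flat. Compound 4 is accordingly expected to give about 45000 nM, within a range of 20000 nM to 100000 nM, and most likely to be reported again only as a limit.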

Compound 4, half-maximal inhibitory concentration: > 40000 nM
Compound 4 was reported as a limit (the forecaster's own chance of this, stated with the estimate: 75%); the middle value is on the limit's open side.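

No step from compound 2 to compound 4 can be read in this assay, because each of the two compounds is reported only as a limit: the limit of > 40000 nM in this assay, at which 3 of the 4 values shown sit.

The compounds shown leave open whether the configuration at the saturated chain carbon, drawn S in compound 2 and R in compound 4, changes the result in this assay at all.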